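A few compounds are considered here, and "the series" means these few. Any claim that something is new, unique, unknown or untested is made for them only; others in the source may bear on it.

Measured compounds:
- compound 1, `O[C@H]1[C@@H](O)CN[C@@H]1CN[C@@H](COCc1ccccc1)c1ccccc1`: 68300 nM
- compound 2, `O[C@H]1[C@@H](O)CN[C@@H]1CCNc1ccccc1`: 123000 nM
- compound 3, `OCC(O)[C@H]1NC[C@H](O)[C@@H]1O`: 229000 nM

These three compounds were tested in an assay on isolated protein for inhibition of alpha-mannosidase 2 (Homo sapiens); a higher number here means a weaker inhibitor, a lower number a stronger inhibitor. Compound 1 gives the lowest number of the three. Its nearest neighbour is compound 2, whose number lies within the scatter of that of compound 1, so no order between the two can be read from this assay. Compound 3 gives the highest number, and its gap to compound 1 lies beyond the scatter. No pair of these compounds differs in only one place, so no step can be computed among them.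

Compound 4, `O[C@H]1[C@@H](O)CN[C@@H]1CN[C@@H](COCOc1ccc(F)cc1)c1ccccc1`, has not yet been measured in this assay. It differs from compound 1 in one place: 4-fluorophenoxy in place of phenyl on a saturated chain carbon bound to an oxygen on a saturated carbon. Among the measured compounds shown here, nothing among the measured compounds shows how such a change plays out, since no step between them is known. Without such a step, the expectation rests on the small size of the change at the outer end of the chain of compound 1: a step from compound 1 to compound 4 that stays within the scatter, or is at most modest, in either direction. The estimate for compound 4 in this assay is 55000 nM, with a range from 15000 nM to 200000 nM, which corresponds to an expected step of a 1.2-fold lower number from compound 1 to compound 4 (0.09 log units; within the scatter).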

Compound 4, inhibition constant: 6470 nM
For compound 4 the middle estimate is 8.5-fold (0.93 log units) above the measured one, and the stated range ends above it.
By their numbers in this assay, from the lowest: compound 4; then compounds 1, 2 and 3 (each within the scatter of the next, the first and the last beyond it).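

In this assay, the change of phenyl to 4-fluorophenoxy on a saturated chain carbon bound to an oxygen on a saturated carbon gives an 11-fold lower number from compound 1 to compound 4 (1.02 log units; beyond the scatter), so this position clearly responds to what it carries. The earlier compounds shown here offered no step at all, and this one shows that the outer end of the chain can move the number well beyond the scatter, here towards a stronger inhibitor. Nothing available bears on why this change has so large an effect.

The change brings in an oxygen and a fluorine together, so this single step cannot show how much each one contributes; a plain phenoxy group and a 4-fluorophenyl group in the same place would separate the two. Going by these compounds, it also remains open whether the gain depends on the fluorine standing where it does on the ring, and whether another group at that ring position, such as chlorine, methoxy or an amine, or a longer chain leading to the ring, would hold or extend it.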